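A Piperidine Urea in Place of the Difluorocyclohexyl Amide

The source may report more compounds than this note shows. Statements on the series, on what has been measured and on what is new or still open speak of the compounds shown alone.

Compound 1 `O=C(C1CCC(F)(F)CC1)N1CC(c2nc(-c3cccc(Cl)c3)no2)C1`: 180 nM
Compound 2 `O=S(=O)(c1ccc(Cl)cc1)N1CC(c2nc(-c3cccc(Cl)c3)no2)C1`: > 10000 nM

For the measured compounds named here, compound 1 is the only compound with a number in an assay on HEK293 cells for positive allosteric modulation of metabotropic glutamate receptor 5 (Homo sapiens), read by FLIPR; a higher number here means that more compound is needed for the effect, a lower number that less compound is needed; there compound 1 gives 180 nM. Compound 2 reaches only a limit in this assay, > 10000 nM, which is the limit of > 10000 nM in this assay, at which 1 of the 2 values shown sits. Going by the values given here, no step between two measured compounds is available, so nothing measured here anchors the change itself. Compound 3 `COC1CCN(C(=O)N2CC(c3nc(-c4cccc(Cl)c4)no3)C2)CC1` differs from compound 1 by 4-methoxypiperidin-1-yl in place of 4,4-difluorocyclohexyl on a carbonyl carbon. A modest weakening, at or slightly beyond the scatter, is expected for compound 3: the estimated step is a 2.2-fold higher number from compound 1 to compound 3 (0.35 log units; beyond the scatter). Compound 3 is thus expected to give about 400 nM, between 120 nM and 1500 nM.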

Compound 3, half-maximal effective concentration: > 10000 nM
Compound 3 ended at the assay's limit (the forecaster's own chance of this, stated with the estimate: 15%); at least 25-fold (1.39 log units) between middle value and limit.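

In this assay, for the compounds shown here, the carbonyl carbon of the core of compound 1 proves far less tolerant than the earlier compounds could show: 4-methoxypiperidin-1-yl in place of 4,4-difluorocyclohexyl gives an at least 55-fold higher number from compound 1 to compound 3 (1.74 log units; beyond the scatter). Both groups are six-membered non-aromatic rings, so a ring of this size alone does not preserve the effect. For compound 3, > 10000 nM is a limit of the assay and not a number, so the step's full size stays unknown: the limit of > 10000 nM in this assay, at which 2 of the 3 values shown sit.

The compounds shown leave open whether the loss follows the ring nitrogen or the methoxy group. A 4,4-difluoropiperidin-1-yl group on the same carbonyl carbon would separate the two.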